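The source may report more compounds than this note shows. Statements on the series, on what has been measured and on what is new or still open speak of the compounds shown alone.

In a functional assay on isolated protein for antagonist activity at muscarinic acetylcholine receptor M5 (Homo sapiens), read by calcium flux (on this read-out lower numbers stand for stronger inhibition and higher numbers for weaker inhibition), compound 1 `Cn1cc(S(=O)(=O)N2CCC3(CC2)OCCS3)cn1` gives > 10000 nM, which is a limit of the assay and not a number. Compound 2 `O=S(=O)(c1ccc(F)c(Cl)c1)N1CCC2(CC1)OCCS2` likewise gives > 10000 nM in this assay, again only a limit. Going by the values given here, both values sit at the limit of > 10000 nM in this assay, at which 2 of the 2 values shown sit, so compound 2 stands at the same limit as the only other value shown. Compound 3 `O=S(=O)(c1ccc(F)c(F)c1)N1CCC2(CC1)OCCS2` differs from compound 2 by fluoro in place of chloro on an aromatic carbon. Among the compounds with values here, no step between measured compounds is known; the expected change, a step that the limit leaves unreadable from compound 2 to compound 3, is none beyond the scatter. Compound 3 is therefore estimated at 20000 nM, between 5000 nM and 80000 nM, and is expected most likely to be reported again only as a limit.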

Compound 3, half-maximal inhibitory concentration: > 10000 nM
Compound 3: only a limit was reported; the forecaster's own chance of this, stated with the estimate: 85%; the middle value is on the limit's open side.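

Compound 2 and compound 3 both stand only as limits, so no step can be read for fluoro in place of chloro. In this assay, on these data alone, it stays open whether any compound on the shared core gives a measured number rather than a limit.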